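Opening a protected diol on the triazole side chain

This account rests on a few compounds, and the source may have more. Where it says the series, first, only, none or still open, it means among the compounds named here.

Among the compounds with values here, compound 2 `CC1(C)OCC(Cn2cc(Cn3c4c(c5ccccc53)C(=O)c3c[n+]([O-])c5ccccc5c3C4=O)nn2)O1` stands as the lowest of the two numbers measured so far in a functional assay on MDA-MB-231 cells (Homo sapiens) for cytotoxicity, read by MTT assay, with a stated time of 72 h; on this read-out lower numbers stand for stronger inhibition and higher numbers for weaker inhibition: compound 2 gives 230 nM. Within the data shown here, its only measured neighbour is compound 1 `O=C1c2c[n+]([O-])c3ccccc3c2C(=O)c2c1c1ccccc1n2Cc1cn([C@H]2O[C@H](CO)[C@@H](O)[C@H]2O)nn1`, which in this assay gives 1700 nM; the step of a 7.4-fold lower number from compound 1 to compound 2 (0.87 log units; beyond the scatter) separates them, and it came with (2,2-dimethyl-1,3-dioxolan-4-yl)methyl in place of 3,4-dihydroxy-5-(hydroxymethyl)oxolan-2-yl on an aromatic nitrogen. Compound 3 `O=C1c2c[n+]([O-])c3ccccc3c2C(=O)c2c1c1ccccc1n2Cc1cn(C[C@@H](O)CO)nn1` is not yet measured. It differs from compound 2 in one place: 1,2-dihydroxyethyl in place of 2,2-dimethyl-1,3-dioxolan-4-yl on a saturated chain carbon bound to an aromatic nitrogen. Among the measured compounds shown here, the single measured step bears on this only loosely: compound 1, carrying 3,4-dihydroxy-5-(hydroxymethyl)oxolan-2-yl, gave the higher number, whereas compound 2, carrying the 2,2-dimethyl-1,3-dioxolan-4-yl group, gave the lower one. Compound 3 carries 2,3-dihydroxypropyl, so a rise in the number is expected, though a rise smaller than a 7.4-fold lower number from compound 1 to compound 2 (0.87 log units; beyond the scatter) is anticipated. Compound 3 is therefore estimated at 600 nM, within 200 nM to 2500 nM. That expectation means a step of a 2.6-fold higher number from compound 2 to compound 3 (0.42 log units; beyond the scatter).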

Compound 3, half-maximal inhibitory concentration: 670 nM
Compound 3: the middle estimate sits 1.1-fold (0.05 log units) below what was measured; the measured number falls inside the stated range.
By their numbers in this assay, from the lowest: compound 2; then compound 3; then compound 1.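

In this assay, the open diol and the closed ring can now be compared directly: 1,2-dihydroxyethyl in place of 2,2-dimethyl-1,3-dioxolan-4-yl, a change that removes a ring and goes from 0 to 2 hydrogen-bond donors, gives a 2.9-fold higher number from compound 2 to compound 3 (0.46 log units; beyond the scatter) and leaves the closed ring with the lower number. Free hydroxyl groups alone do not fix the number at this position: both groups in the next comparison carry them, yet 2,3-dihydroxypropyl in place of 3,4-dihydroxy-5-(hydroxymethyl)oxolan-2-yl on the aromatic nitrogen gives a 2.5-fold lower number from compound 1 to compound 3 (0.40 log units; beyond the scatter) and places compound 3 between the other two compounds. No measurement is available to explain either shift.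

With only three side chains, the contributions of the ring, the chain and the hydroxyl groups cannot be separated from one another. Going by these compounds, it remains open how a single hydroxyl, a primary amine, a carboxylic acid or a longer chain ending in a diol would read here, and whether the opposite stereocentre of the 1,2-dihydroxyethyl group would change the number.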